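Anilino halogen swap: bromo to iodo in compound 4

This account rests on a few compounds, and the source may have more. Where it says the series, first, only, none or still open, it means among the compounds named here.

Values from a functional assay on MCF7 cells (Homo sapiens) for inhibition, read by sulforhodamine B assay; a higher number here means a weaker inhibitor, a lower number a stronger inhibitor:
- compound 1, `O=C1C(Nc2ccccc2)=CC(=O)c2c1nc1n2[C@H]2OC[C@@H](O)[C@H]2OC1`: > 4000 nM, which is a limit of this assay and not a number
- compound 2, `O=C1C=C(Nc2ccc(Br)cc2)C(=O)c2c1nc1n2[C@H]2OC[C@@H](O)[C@H]2OC1`: 2580 nM
- compound 3, `COc1cccc(NC2=CC(=O)c3c(nc4n3[C@H]3OC[C@@H](O)[C@H]3OC4)C2=O)c1`: 3830 nM

Compound 2 has the lowest of the two numbers; compound 3 sits within the scatter of it, so no order between the two is claimed. Within the data shown here, the only measured step, an at least 1.0-fold lower number from compound 1 to compound 3 (0.01 log units; that floor lies within the scatter), starts from a limit (the limit of > 4000 nM in this assay, at which 1 of the 3 values shown sits) and concerns a methoxy group, not a halogen, so it says nothing about the change from compound 2 to compound 4. Compound 4, `O=C1C=C(Nc2ccc(I)cc2)C(=O)c2c1nc1n2[C@H]2OC[C@@H](O)[C@H]2OC1`, differs from compound 2 by iodo in place of bromo on an aromatic carbon. Among the measured compounds shown here, no measured step bears on swapping one halogen for another, so a step no larger than the scatter is expected in this assay, in no particular direction. Compound 4 is therefore estimated at 2500 nM (1200 nM to 5000 nM). That means a 1.0-fold lower number from compound 2 to compound 4 (0.01 log units; within the scatter) is expected.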

Compound 4, half-maximal inhibitory concentration: 2230 nM
Estimate against measurement, compound 4: 1.1-fold (0.05 log units) above, and the stated range covers the measured number.
By their numbers in this assay, from the lowest: compounds 4, 2 and 3 (each within the scatter of the next). At a limit, above all of these: compound 1.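

Iodo in place of bromo, para to a large group, gives in this assay a 1.2-fold lower number from compound 2 to compound 4 (0.06 log units; within the scatter). The earlier compounds shown here held no pair of halogens at this position, and this pair shows that the two are not told apart here.

On these data alone, whether a halogen at this position differs from hydrogen cannot be read, since compound 1 stands at a limit and not at a number: the limit of > 4000 nM in this assay, at which 1 of the 4 values shown sits. How an amine or a carboxylic acid in place of the halogen would read also stays open.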